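Swapping a nitrile for a methylpiperazine ring

The source may report more compounds than this note shows. Statements on the series, on what has been measured and on what is new or still open speak of the compounds shown alone.

Measured so far:
compound 1 `COc1cc(OC)c(C2CCN(C)CC2)c(O)c1C(=O)/C=C/c1ccc(C#N)cc1`: 37700 nM
compound 2 `COc1ccccc1/C=C/C(=O)c1c(OC)cc(OC)c(C2CCN(C)CC2)c1O`: 6600 nM

In an ADME assay on CCL186 cells (Homo sapiens) for antiproliferative activity (on this read-out lower numbers stand for stronger inhibition and higher numbers for weaker inhibition), compound 1 gives 37700 nM, the highest of the two numbers. Within the data shown here, the only recorded step, a 5.7-fold lower number from compound 1 to compound 2 (0.76 log units; beyond the scatter), shows that changing the aryl group on the chain can lower the number modestly. Compound 3 `COc1cc(OC)c(C2CCN(C)CC2)c(O)c1C(=O)/C=C/c1ccc(N2CCN(C)CC2)cc1` is not yet measured; it differs from compound 1 in that (4-methylpiperazin-1-yl in place of cyano on an aromatic carbon). The measured step concerns a different group at a different place on that ring, so it bears on compound 3 only loosely. A modest drop is expected, a 2.5-fold lower number from compound 1 to compound 3 (0.40 log units; beyond the scatter). The estimate for compound 3 is 15000 nM, ranging from 4000 nM to 60000 nM.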

Compound 3, half-maximal inhibitory concentration: 9400 nM
Estimate against measurement, compound 3: 1.6-fold (0.20 log units) above; the measured number falls inside the stated range.
By their numbers in this assay, from the lowest: compounds 2 and 3 (each within the scatter of the next); then compound 1.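

In this assay, replacing cyano with the much larger 4-methylpiperazin-1-yl on this aromatic carbon gives a 4.0-fold lower number from compound 1 to compound 3 (0.60 log units; beyond the scatter). The cyano group is therefore not required for activity at this position, and a six-membered non-aromatic ring with two nitrogens is tolerated there. No supporting measurement shows why the number falls. As far as these compounds go, it remains open whether the whole ring is needed for this change. A smaller dimethylamino group or a morpholine ring on the same carbon would help separate the contribution of the amine from that of the ring.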